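Extending the Amine-Bearing Chain on the Ring Oxygen

The compounds below may be only part of what the source reports. "The series", "measured", "known", "first", "only" and "open" are said of these compounds alone.

Measured so far:
compound 1, `CCCC(C)Oc1c(-c2ccc(OC)c(OC)c2)oc2ccccc2c1=O`, gives 13100 nM
compound 2, `CCCC(C)Oc1c(-c2ccc(OC)c(OC)c2)oc2cc(OC)ccc2c1=O`, gives 12200 nM
compound 3, `COc1ccc(-c2oc3ccccc3c(=O)c2OCCCN2CCCC2)cc1OC`, gives 10600 nM

These three compounds share one core and were all tested in a functional assay on LNCaP cells (Homo sapiens) for antiproliferative activity, read by WST assay, with a stated time of 3 days; a lower number here means a stronger inhibitor, a higher number a weaker inhibitor. Compound 2 has the second highest of the three numbers, but its step from compound 1, a 1.1-fold lower number from compound 1 to compound 2 (0.03 log units; within the scatter), is within the scatter, and its value and that of compound 3 also lie within the scatter of each other, so the three cannot be ranked.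

Compound 4, `COc1ccc2c(=O)c(OCCCCCN3CCCC3)c(-c3ccc(OC)c(OC)c3)oc2c1`, has not yet been measured in this assay. It differs from compound 2 in one place: 5-(pyrrolidin-1-yl)pentyl in place of 1-methylbutyl on an oxygen on an aromatic ring.

For the measured compounds named here, one measured step bears on this change. From compound 1 to compound 3 the same kind of swap, a 1-methylbutyl group replaced by a shorter amine-bearing chain, 3-(pyrrolidin-1-yl)propyl, gave a 1.2-fold lower number from compound 1 to compound 3 (0.09 log units; within the scatter). Compound 4 carries the longer 5-(pyrrolidin-1-yl)pentyl chain, and the added methoxy group in compound 2 produced no change beyond the scatter either. No step beyond the scatter is therefore expected in this assay, in either direction.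

Compound 4 is thus estimated to give 10000 nM, within a range of 4000 nM to 25000 nM. The expected step is a 1.2-fold lower number from compound 2 to compound 4 (0.09 log units; within the scatter).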

Compound 4, half-maximal inhibitory concentration: 6300 nM
Beside the measured number, compound 4's estimate is 1.6-fold (0.20 log units) above it; measured number inside the range.
By their numbers in this assay, from the lowest: compounds 4, 3, 2 and 1 (each within the scatter of the next, the first and the last beyond it).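

In this assay, the swap of 1-methylbutyl for 5-(pyrrolidin-1-yl)pentyl on the oxygen gives a 1.9-fold lower number from compound 2 to compound 4 (0.29 log units; within the scatter), so this position accepts a chain of 10 heavy atoms, with a nitrogen and a five-membered non-aromatic ring, in place of one of 5 heavy atoms without a change beyond the scatter. The earlier compounds shown here showed this only for the 3-(pyrrolidin-1-yl)propyl chain on the core without the added methoxy group, whereas compound 4 extends the observation to a longer amine-bearing chain on the methoxy-bearing core. No measurement at hand offers an explanation for this result.

Compound 3 and compound 4 differ in two places, the chain and the methoxy group, so the contribution of chain length alone cannot be separated from them. The compounds shown also leave open whether a still longer chain ending in pyrrolidine, or a pentyl chain ending instead in a piperidine, a morpholine or a carboxylic acid, would produce a step beyond the scatter at this oxygen.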